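Exchanging One Halogenated Phenyl Ring for Another

This account rests on a few compounds, and the source may have more. Where it says the series, first, only, none or still open, it means among the compounds named here.

Of the compounds shown here, three sharing a core have been tested in a functional assay on MDA-MB-231 cells (Homo sapiens) for inhibition, read by MTT assay, with a stated time of 48 h; a higher number here means a weaker inhibitor, a lower number a stronger inhibitor. Compound 1 `COc1cc(-c2cc(/C=C3\Cc4ccccc4C3=O)[nH]n2)cc(OC)c1OC` gives 7100 nM in this assay, and compound 2 `COc1ccc(-c2cc(/C=C/C(=O)c3ccc(N)cc3)[nH]n2)cc1OC` gives 2200 nM. Compound 3 `COc1cc(-c2cc(/C=C/C(=O)c3ccc(Cl)cc3)[nH]n2)cc(OC)c1OC` gives 26000 nM, the highest of the three numbers, and its gaps to both other compounds lie beyond the scatter, so it is the weakest inhibitor of the three. Compound 4 `COc1cc(-c2cc(/C=C/C(=O)c3ccc(F)c(F)c3)[nH]n2)cc(OC)c1OC` differs from compound 3 in one place: 3,4-difluorophenyl in place of 4-chlorophenyl on a carbonyl carbon. Within the data shown here, no measured pair shows what such an exchange does, so the expectation rests on compound 3 alone. Only a small step, if any, is expected, estimated at a 1.4-fold lower number from compound 3 to compound 4 (0.16 log units; within the scatter), within the scatter. Compound 4 is accordingly expected to give about 18000 nM, in a range from 6000 nM to 50000 nM.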

Compound 4, half-maximal inhibitory concentration: 1500 nM
Beside the measured number, compound 4's estimate is 12-fold (1.08 log units) above it, outside the stated range (below it).
By their numbers in this assay, from the lowest: compounds 4 and 2 (each within the scatter of the next); then compound 1; then compound 3.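

This position on the carbonyl carbon proves sensitive: with the rest of the molecule unchanged, 3,4-difluorophenyl in place of 4-chlorophenyl gives a 17-fold lower number from compound 3 to compound 4 (1.24 log units; beyond the scatter) in this assay. The weak result of compound 3 is therefore not fixed by the rest of its structure, since the group on this carbon alone can move the number this far. Nothing at hand explains the size of this step. On these data alone, whether it comes from losing the chlorine or from gaining the two fluorines stays open. A plain phenyl ring, or a phenyl ring carrying a single fluorine, on this carbon would help separate the two.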